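Losing the Nitrile: From Compound 3 to Compound 4

The source may hold more compounds than are shown below. What is called first, only, known or untested is meant among the compounds shown, and "the series" means these compounds.

Measured in a functional assay on MCF7 cells (Homo sapiens) for cytotoxicity, read by CellTiter-Glo, with a stated time of 5 days (a higher number here means a weaker inhibitor, a lower number a stronger inhibitor), as follows
compound 1 `CC/C(=C(/c1ccc(/C=C/C(=O)O)cc1)c1ccc2[nH]ncc2c1)c1ccccc1` gives 6 nM
compound 2 `CC/C(=C(/c1ccc(/C=C/C(=O)O)cc1)c1ccc2[nH]ncc2c1)c1ccc(Cl)cc1` gives 15 nM
compound 3 `CC/C(=C(/c1ccc(/C=C/C(=O)O)cc1)c1ccc2[nH]ncc2c1)c1ccc(C#N)cc1` gives 47 nM

Compound 3 stands highest of the three at 47 nM in this assay and is thus the weakest inhibitor among them. The next compound, compound 4 `CC/C(=C(/c1ccc(/C=C/C(=O)O)cc1)c1ccc2[nH]ncc2c1)c1ccccc1C`, differs from it by one exchange (2-methylphenyl in place of 4-cyanophenyl on a double-bonded chain carbon bound to a double-bonded chain carbon and a saturated chain carbon), which puts 2-methylphenyl in place of 4-cyanophenyl on a double-bonded chain carbon bound to a double-bonded chain carbon and a saturated chain carbon.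

Within the data shown here, three measured steps bear on this exchange. Adding the cyano group gave a 7.8-fold higher number from compound 1 to compound 3 (0.89 log units; beyond the scatter) in the largest of them. Adding chloro gave a 2.5-fold higher number from compound 1 to compound 2 (0.40 log units; beyond the scatter) as a smaller step, and replacing chloro with cyano gave a 3.1-fold higher number from compound 2 to compound 3 (0.50 log units; beyond the scatter) as the third. Among the measured compounds shown here, both substituents measured so far raised the number, but no measured compound carries a 2-methylphenyl group, so the effect of that methyl is unknown. Compound 4 is therefore expected to lie above or near compound 1 at 6 nM but clearly under compound 3. The expected change is modest, an estimated 4.7-fold lower number from compound 3 to compound 4 (0.67 log units; beyond the scatter) in the direction of a stronger inhibitor. In this assay the estimate for compound 4 is 10 nM with a range from 3 nM to 35 nM expected.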

Compound 4, half-maximal inhibitory concentration: 4 nM
The estimate for compound 4 lay 2.5-fold (0.40 log units) above the measured number; low and high end bracket the measured number.
By their numbers in this assay, from the lowest: compounds 4 and 1 (each within the scatter of the next); then compound 2; then compound 3.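

In this assay, 2-methylphenyl in place of 4-cyanophenyl on the double-bonded chain carbon gave a 12-fold lower number from compound 3 to compound 4 (1.07 log units; beyond the scatter), the largest step among these compounds, and 2-methylphenyl in place of 4-chlorophenyl gave a 3.8-fold lower number from compound 2 to compound 4 (0.57 log units; beyond the scatter). Adding the methyl of 2-methylphenyl gave a 1.5-fold lower number from compound 1 to compound 4 (0.18 log units; within the scatter), so this position carries a substituent here without the change beyond the scatter that came with chloro and cyano, although the methyl differs from those two groups both in its identity and in its place on the ring. Nothing available accounts for this difference between the substituents.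

The compounds shown do not separate the identity of the substituent from its place on the ring, and a 4-methylphenyl or a 2-chlorophenyl group at the same chain carbon would be needed to tell these two apart. Going by these compounds, it also remains open how far this result extends to other groups on the ring, such as a longer chain in 2-ethylphenyl or an amine in 2-aminophenyl.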